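The compounds below may be only part of what the source reports. "The series", "measured", "known", "first", "only" and "open" are said of these compounds alone.

Measured in a functional assay on B16 cells (Mus musculus) for antiproliferative activity, read by MTT assay, with a stated time of 72 h; on this read-out higher numbers stand for weaker inhibition and lower numbers for stronger inhibition:
- compound 1 `COc1cc(/C(=C/c2ccc(C)cc2)C(C)O)cc(OC)c1OC`: > 100000 nM
- compound 2 `COc1cc(/C(=C/c2ccc([N+](=O)[O-])cc2)C(C)O)cc(OC)c1OC`: > 100000 nM
- compound 3 `COc1ccc(/C=C(/c2cc(OC)c(OC)c(OC)c2)C(C)O)cc1OC`: > 100000 nM

Compound 3 gives > 100000 nM in this assay, and this is a limit of the assay, not a number. It has no readable place in the series, for the other two values shown are limits as well: the limit of > 100000 nM in this assay, at which 3 of the 3 values shown sit.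

Compound 4 `COc1ccc(/C=C(/c2cc(OC)c(OC)c(OC)c2)C(C)O)cc1[N+](=O)[O-]` is compound 3 with one change, nitro in place of methoxy on an aromatic carbon.

Among the compounds with values here, only one measured step brings in a nitro group on an aromatic carbon, and there it replaces methyl: a step that the two limits leave unreadable from compound 1 to compound 2. That step has no readable size, so it offers no measure for the change at hand and gives no direction. Compound 2 carries a nitro group and still gives > 100000 nM, again a limit. On that evidence, no gain in this assay beyond the scatter is expected, although a change of a different kind cannot be ruled out from these data. The expected step is a number no higher from compound 3 to compound 4 (the limit leaves the size open). For compound 4 the estimate is 100000 nM, with an expected range from 15000 nM to 300000 nM, and the assay may well report only a limit again.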

Compound 4, half-maximal inhibitory concentration: > 100000 nM
Compound 4 was reported as a limit; the forecaster's own chance of this, stated with the estimate: 70%; the middle value lies on the limit itself.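

In this assay, no new step can be read between compound 3 and compound 4, since both values are limits and not numbers: the limit of > 100000 nM in this assay, at which 4 of the 4 values shown sit.

The compounds shown leave open how strongly any of them inhibits in this assay, and whether nitro in place of methoxy on an aromatic carbon changes that inhibition at all.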